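Adding Bromine to a Triazole-Bearing Cytotoxic Scaffold

The source may report more compounds than this note shows. Statements on the series, on what has been measured and on what is new or still open speak of the compounds shown alone.

Compound 3 `C=C1C[C@]23C[C@@]1(O)CC[C@H]2c1ccc(O)c(C)c1[C@@H]3Cn1cc(-c2ccc(C(F)(F)F)cc2)nn1` is tested in a functional assay on MCF7 cells (Homo sapiens) for cytotoxicity, read by MTT assay, with a stated time of 4 days (a higher number here means a weaker inhibitor, a lower number a stronger inhibitor), where compound 3 gives 12400 nM. That is the highest of the two numbers measured, and the value of compound 2 `C=C1C[C@]23C[C@@]1(O)CC[C@H]2c1cc(Br)c(O)c(C)c1[C@@H]3Cn1cc(-c2ccc(Cl)cc2)nn1`, which gives 10200 nM, lies within the scatter of it. Compound 1 `C=C1C[C@]23C[C@@]1(O)CC[C@H]2c1cc(Br)c(O)c(C)c1[C@@H]3Cn1cc(-c2ccc(C)cc2)nn1` reaches only the limit > 20000 nM in this assay. Compound 4 `C=C1C[C@]23C[C@@]1(O)CC[C@H]2c1cc(Br)c(O)c(C)c1[C@@H]3Cn1cc(-c2ccc(C(F)(F)F)cc2)nn1` differs from compound 3 by bromo in place of hydrogen on an aromatic carbon. Within the data shown here, the single measured step, an at least 1.9-fold lower number from compound 1 to compound 2 (0.29 log units; that floor lies within the scatter), alters a different part of the molecule and does not bear on this change. Both compounds that carry the bromo group sit at weak values, and no step beyond the scatter is expected for compound 4. Compound 4 is estimated at 13000 nM, with a range from 6000 nM to 30000 nM. The expected step is a 1.0-fold higher number from compound 3 to compound 4 (0.02 log units; within the scatter).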

Compound 4, half-maximal inhibitory concentration: 8100 nM
Compound 4: the middle estimate sits 1.6-fold (0.21 log units) above what was measured, and the stated range covers the measured number.
By their numbers in this assay, from the lowest: compounds 4, 2 and 3 (each within the scatter of the next). At a limit, above all of these: compound 1.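

Placing bromo on the aromatic carbon ortho to a hydroxy group gives a 1.5-fold lower number from compound 3 to compound 4 (0.18 log units; within the scatter) in this assay, so this position carries the added atom without a change that stands clear of the scatter. Among these compounds, with bromo present, trifluoromethyl in place of chloro gives a 1.3-fold lower number from compound 2 to compound 4 (0.10 log units; within the scatter), while trifluoromethyl in place of methyl gives an at least 2.4-fold lower number from compound 1 to compound 4 (0.39 log units; beyond the scatter), the only step here beyond the scatter. That step is a floor, not an exact size, because compound 1 stands at a limit: the limit of > 20000 nM in this assay, at which 1 of the 4 values shown sits.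

As far as these compounds go, whether an amine or a longer chain at this position would shift the number stays open.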